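The compounds below may be only part of what the source reports. "The series", "measured", "known", "first", "only" and "open" are said of these compounds alone.

Measured compounds:
compound 1 `Nc1nonc1C(=O)Nc1cc(C(F)(F)F)cc(C(F)(F)F)c1` — > 100000 nM
compound 2 `O=C(Nc1cc(C(F)(F)F)cc(C(F)(F)F)c1)c1nonc1O` — > 100000 nM

In an assay on isolated protein for inhibition of mitogen-activated protein kinase kinase kinase 14 (Homo sapiens), read by ADP-Glo, with a stated time of 60 min, in the presence of a further agent that is not named here (a lower number here means a stronger inhibitor, a higher number a weaker inhibitor), compound 1 gives only a limit, > 100000 nM. Compound 2 likewise gives only a limit in this assay, > 100000 nM. The step that the two limits leave unreadable from compound 1 to compound 2 therefore cannot be read, as the limit of > 100000 nM in this assay, at which 2 of the 2 values shown sit, shows: both values rest at the same limit, and neither a direction nor a size follows from them. Among the measured compounds shown here, compound 2 thus stands at the limit of this assay, with no number beneath it, and the one further value shown is a limit as well.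

Compound 3 `Cn1cc(C(=O)Nc2cc(C(F)(F)F)cc(C(F)(F)F)c2)c(O)n1` differs from compound 2 by 3-hydroxy-1-methyl-1H-pyrazol-4-yl in place of 4-hydroxy-1,2,5-oxadiazol-3-yl on a carbonyl carbon. No measured step in this series bears on this change; the single step shown is unreadable, and the evidence in the limit of > 100000 nM in this assay, at which 2 of the 2 values shown sit, gives no footing for a direction in this assay. Compound 3 is accordingly expected to stay at the limit, estimated at 100000 nM with a range from 30000 nM to 100000 nM. The step of a number no higher from compound 2 to compound 3 (the limit leaves the size open) is expected to show no change that can be read beyond the scatter.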

Compound 3, half-maximal inhibitory concentration: > 100000 nM
Compound 3 was reported as a limit (the forecaster's own chance of this, stated with the estimate: 85%); the middle value sits exactly at the limit.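

Compound 3 gives > 100000 nM in this assay, which is a limit and not a number. Among the compounds shown here, no step among compound 1, compound 2 and compound 3 can therefore be read: the limit of > 100000 nM in this assay, at which 3 of the 3 values shown sit. Still open, from the compounds shown here alone, is whether any of these three compounds has a measurable inhibitory value, and what direction or size their changes on the carbonyl carbon would take.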